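Chlorophenyl swap on compound 1

The source may report more compounds than this note shows. Statements on the series, on what has been measured and on what is new or still open speak of the compounds shown alone.

Values in a physicochemical assay for solubility, measured as kinetic solubility; on this read-out higher numbers stand for higher solubility and lower numbers for lower solubility:
compound 1 `CNC(=O)c1cc(C(=O)N[C@H]2CC[C@H](O)CC2)n([C@@H](C)c2cccc(Cl)c2)n1`: >= 143 ug/mL (limit)
compound 2 `CNC(=O)c1cc(C(=O)N[C@H]2[C@@H]3C[C@H](O)C[C@@H]32)n([C@@H](C)c2cccc(Cl)c2)n1`: >= 168 ug/mL (limit)

Going by the values given here, compound 1 stands only at a limit, with >= 143 ug/mL as its sole reading and no number behind it. Compound 2 likewise gives only a limit, >= 168 ug/mL. Among the compounds with values here, the one measured step is a step that the two limits leave unreadable from compound 1 to compound 2. It lies on the amide-type nitrogen, away from the chlorophenyl, and offers no size to carry over.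

Compound 3 `CNC(=O)c1cc(C(=O)N[C@H]2CC[C@H](O)CC2)n([C@@H](C)c2ccccc2Cl)n1` has the same atoms as compound 1, joined differently: 2-chlorophenyl in place of 3-chlorophenyl on a saturated chain carbon bound to an aromatic nitrogen and a saturated chain carbon. That is 2-chlorophenyl in place of 3-chlorophenyl on a saturated chain carbon bound to an aromatic nitrogen and a saturated chain carbon. Within the data shown here, no measured step touches this place, so no direction can be read, and no change beyond the scatter is expected in this assay. The expected step is a step that the limit leaves unreadable from compound 1 to compound 3. Compound 3 is estimated at 150 ug/mL, with an expected range of 80 ug/mL to 200 ug/mL.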

Compound 3, solubility: >= 182 ug/mL
Compound 3: only a limit was reported; the forecaster's own chance of this, stated with the estimate: 55%; at least 1.2-fold (0.08 log units) between middle value and limit.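

Compound 1 and compound 3 both stand only at limits in this assay, so the step between them cannot be read. What the compounds shown leave open is whether 2-chlorophenyl in place of 3-chlorophenyl shifts this read-out at all, and in which direction.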